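A few compounds are considered here, and "the series" means these few. Any claim that something is new, unique, unknown or untested is made for them only; others in the source may bear on it.

Going by the values given here, in a functional assay on PC-3 cells (Homo sapiens) for cytotoxicity, read by MTT assay, with a stated time of 48 h (on this read-out lower numbers stand for stronger inhibition and higher numbers for weaker inhibition), compound 3 `CCN(CC)CC(=O)N1N=C(C)CC1c1ccccc1OC(C)=O` gives 51200 nM, the highest of the three numbers measured so far. Compound 1 `CCN(CC)CC(=O)N1N=C(C)CC1c1ccccc1O` gives 25900 nM, and compound 2 `CC1=NN(C(=O)CN2CCCCC2)C(c2ccccc2O)C1` gives 5890 nM. Compound 4 `CC(=O)Oc1ccccc1C1CC(C)=NN1C(=O)CN1CCCCC1` is not yet measured; it differs from compound 3 by piperidin-1-yl in place of diethylamino on a saturated chain carbon bound to a carbonyl carbon. The same change has been seen once before: a 4.4-fold lower number from compound 1 to compound 2 (0.64 log units; beyond the scatter), a step beyond the scatter. The other measured step, a 2.0-fold higher number from compound 1 to compound 3 (0.30 log units; within the scatter), concerns a different place and stays within the scatter, so it bears on this question only indirectly. Compound 3 and compound 4 both carry the acetyl on the oxygen on the aromatic ring, a setting in which the amine exchange has not yet been tested. On that single precedent, compound 4 is expected to show a lower number, a step of a 4.3-fold lower number from compound 3 to compound 4 (0.63 log units; beyond the scatter). In this assay compound 4 is therefore estimated at 12000 nM, between 5000 nM and 30000 nM.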

Compound 4, half-maximal inhibitory concentration: 4070 nM
Compound 4: the middle estimate sits 2.9-fold (0.47 log units) above what was measured; measured number below the stated range.
By their numbers in this assay, from the lowest: compounds 4 and 2 (each within the scatter of the next); then compounds 1 and 3 (each within the scatter of the next).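

In this assay, piperidin-1-yl in place of diethylamino also lowers the number when acetyl sits on the oxygen on the aromatic ring, giving a 13-fold lower number from compound 3 to compound 4 (1.10 log units; beyond the scatter), but the size of the step differs between the two cores: the same change on two cores in this assay, a 4.4-fold lower number (0.64 log units; beyond the scatter) from compound 1 to compound 2 and a 13-fold lower number (1.10 log units; beyond the scatter) from compound 3 to compound 4, 2.9-fold (0.46 log units) apart, beyond the scatter of two such steps. Acetyl in place of hydrogen on that oxygen gives a 1.4-fold lower number from compound 2 to compound 4 (0.16 log units; within the scatter), so the two changes do not simply add: the same change on two cores in this assay, a 2.0-fold higher number (0.30 log units; within the scatter) from compound 1 to compound 3 and a 1.4-fold lower number (0.16 log units; within the scatter) from compound 2 to compound 4, 2.9-fold (0.46 log units) apart, beyond the scatter of two such steps. The compounds shown leave open whether a pyrrolidine or a morpholine in place of piperidin-1-yl would follow the same course. They also leave open whether a benzoyl in place of acetyl would keep the number of the piperidin-1-yl compounds.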